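This account rests on a few compounds, and the source may have more. Where it says the series, first, only, none or still open, it means among the compounds named here.

Compound 1 `NC1CCC(Nc2nc(NCc3ccc(-c4ccccc4)cc3)c3ncn(C4CCCC4)c3n2)CC1`: 745 nM
Compound 2 `NC1CCC(Nc2nc(NCc3ccc(-c4cccc(F)c4)nc3)c3ncn(C4CCCC4)c3n2)CC1`: 74 nM

In a functional assay on HCT-116 cells (Homo sapiens) for inhibition, with a stated time of 72 h (on this read-out lower numbers stand for stronger inhibition and higher numbers for weaker inhibition), compound 2 gives 74 nM as the lower of the two numbers, beyond the scatter from compound 1. Compound 3 `NC1CCC(Nc2nc(NCc3ccc(-c4ccco4)nc3)c3ncn(C4CCCC4)c3n2)CC1` has furan-2-yl in place of 3-fluorophenyl on an aromatic carbon. Among the measured compounds shown here, no measured pair of compounds shows this exchange, so any forecast remains uncertain. A small rise in this assay, towards weaker inhibition, is expected, but not one beyond the scatter. The expected change is a 1.5-fold higher number from compound 2 to compound 3 (0.17 log units; within the scatter) in this estimate. Compound 3 is expected at 110 nM (estimated range 35 nM to 350 nM).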

Compound 3, half-maximal inhibitory concentration: 86 nM
Beside the measured number, compound 3's estimate is 1.3-fold (0.11 log units) above it; measured number inside the range.
By their numbers in this assay, from the lowest: compounds 2 and 3 (each within the scatter of the next); then compound 1.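

In this assay, furan-2-yl in place of 3-fluorophenyl gives a 1.2-fold higher number from compound 2 to compound 3 (0.07 log units; within the scatter), so this aromatic carbon accepts a five-membered aromatic ring as well as a six-membered one. The exchange of 4-phenylphenyl for 6-(furan-2-yl)pyridin-3-yl gives an 8.7-fold lower number from compound 1 to compound 3 (0.94 log units; beyond the scatter), so the lower number does not depend on the 3-fluorophenyl group. Nothing measured explains either step.

As far as these compounds go, whether a morpholine or a methyl group on this carbon would hold the number stays open. The compounds shown also do not separate the effect of the ring nitrogen from that of the terminal ring.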